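The compounds below may be only part of what the source reports. "The series", "measured", "known", "first", "only" and "open" are said of these compounds alone.

Compound 3, `COc1ccc(/C(=C(/CCNC(=O)N2CCOCC2)c2ccccc2)c2ccccc2)cc1`, stands alone with a number among the three measured values: in a functional assay on MDA-MB-231 cells (Homo sapiens) for cytotoxicity, read by MTT assay, with a stated time of 72 h (on this read-out lower numbers stand for stronger inhibition and higher numbers for weaker inhibition), compound 3 gives 42800 nM. Compound 1, `COc1ccc(/C(=C(/CCCl)c2ccccc2)c2ccccc2)cc1`, reaches only the limit of this assay, > 50000 nM. Compound 2, `COc1ccc(/C(=C(/CCNC(=O)NC2CCCCC2)c2ccccc2)c2ccccc2)cc1`, likewise reaches only the limit, > 50000 nM. The step of an at least 1.1-fold lower number from compound 1 to compound 3 (0.06 log units; that floor lies within the scatter) and the step of an at least 1.1-fold lower number from compound 2 to compound 3 (0.06 log units; that floor lies within the scatter) are each readable only as floors, and the step that the two limits leave unreadable from compound 1 to compound 2 cannot be read at all, because the limit of > 50000 nM in this assay, at which 2 of the 3 values shown sit, hides the true values of compound 1 and compound 2.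

Compound 4, `COc1ccc(/C(=C(/CCNC(=O)C(=O)NC2CCCCC2)c2ccccc2)c2ccccc2)cc1`, differs from compound 3 in one place: cyclohexylcarbamoyl in place of morpholin-4-yl on a carbonyl carbon. Going by the values given here, the nearest guide is the cyclohexylamino group on a carbonyl carbon in compound 2, which in this assay sat at the limit, while the morpholin-4-yl group of compound 3 gave the single number. Compound 4 carries a cyclohexyl group again, now one carbonyl further out, so the expected outcome in this assay is a weak result, most likely at or beyond the limit; the expected step of a 1.4-fold higher number from compound 3 to compound 4 (0.15 log units; within the scatter) is upward in number. Compound 4 is thus estimated at 60000 nM, within a range from 30000 nM to 150000 nM.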

Compound 4, half-maximal inhibitory concentration: 12200 nM
Compound 4: middle estimate off by 4.9-fold (0.69 log units), on the high side; measured number below the stated range.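

In this assay, going by these compounds alone, this position on the carbonyl carbon gives the first step with a readable size beyond the scatter: a 3.5-fold lower number from compound 3 to compound 4 (0.55 log units; beyond the scatter). A cyclohexyl ring does not by itself hold a compound at the limit: with cyclohexylcarbamoyl on the carbonyl carbon in place of cyclohexylamino, the result is an at least 4.0-fold lower number from compound 2 to compound 4 (0.61 log units; beyond the scatter), and the change from the chloro on the saturated chain carbon to ((cyclohexylcarbamoyl)carbonyl)amino gives an at least 4.0-fold lower number from compound 1 to compound 4 (0.61 log units; beyond the scatter). These last two steps are floors whose full size cannot be read, because compound 1 and compound 2 give no number: the limit of > 50000 nM in this assay, at which 2 of the 4 values shown sit.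

The compounds shown leave open whether the lower number in compound 4 goes with the second carbonyl, the cyclohexyl ring or the amide hydrogen, as compound 4 brings these in together relative to compound 3 and compound 2. Going by these compounds, it also remains open how a phenylamino group or a piperidin-1-yl group on the same carbonyl carbon would read in this assay, and so whether the ring of carbon only matters there.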